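This account rests on a few compounds, and the source may have more. Where it says the series, first, only, none or still open, it means among the compounds named here.

Two compounds share one core and differ only in the group on one aromatic carbon. Compound 1 `CC1(c2ccc(-c3cccc([N+](=O)[O-])c3)cc2)CC(S(=O)(=O)c2ccc(F)cc2)=C(c2ccc(/C(N)=N\O)cc2)O1` gives 11100 nM in an ADME assay on J774.A1 cells (Mus musculus) for cytotoxicity, read by MTT assay, with a stated time of 72 h; a higher number here means that more compound is tolerated, a lower number that less compound is tolerated. For the measured compounds named here, compound 2 `CC1(c2ccc(-c3ccncc3)cc2)CC(S(=O)(=O)c2ccc(F)cc2)=C(c2ccc(/C(N)=N\O)cc2)O1` gives 6750 nM in this assay; the single measured step, a 1.6-fold lower number from compound 1 to compound 2 (0.22 log units; within the scatter), lies within the scatter, so these two numbers cannot be told apart. Compound 3 `CC1(c2ccc(Br)cc2)CC(S(=O)(=O)c2ccc(F)cc2)=C(c2ccc(/C(N)=N\O)cc2)O1` differs from compound 2 in one place: bromo in place of pyridin-4-yl on an aromatic carbon. Going by the values given here, that one step, a 1.6-fold lower number from compound 1 to compound 2 (0.22 log units; within the scatter), swapped one ring for another at this position without a change beyond the scatter, and no measured step involves bromo there. Compound 3 is therefore expected to give 7500 nM, between 3000 nM and 20000 nM, an expected step of a 1.1-fold higher number from compound 2 to compound 3 (0.05 log units; within the scatter) that stays within the scatter.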

Compound 3, half-maximal cytotoxic concentration: 10500 nM
Beside the measured number, compound 3's estimate is 1.4-fold (0.15 log units) below it, and the stated range covers the measured number.
By their numbers in this assay, from the lowest: compounds 2, 3 and 1 (each within the scatter of the next).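

In this assay, bromo at this position gives a number that cannot be told apart from those of the two ring-bearing compounds: a 1.6-fold higher number from compound 2 to compound 3 (0.19 log units; within the scatter), and a 1.1-fold lower number from compound 1 to compound 3 (0.02 log units; within the scatter). The earlier step only swapped one ring for another, whereas this result shows that removing the ring altogether, leaving bromo para to a large group, also stays within the scatter. Nothing available offers a reason for this.

Going by these compounds, whether an amine, a carboxylic acid or a longer chain here would also stay within the scatter remains open. So does whether any group at this position can move the number beyond it.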